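The compounds below may be only part of what the source reports. "The series", "measured", "known", "first", "only" and "open" are said of these compounds alone.

Of the compounds shown here, three have been measured in an assay on cells with melanin-concentrating hormone receptor 1 (Homo sapiens) as the target, read by radioligand binding; on this read-out higher numbers stand for weaker inhibition and lower numbers for stronger inhibition. Compound 1 `CC1CCCCC1Oc1cccc2ccc(N)nc12` gives 32 nM, and compound 3 `Nc1ccc2cccc(OCC3CC4CCC3C4)c2n1` gives 137 nM. Compound 2 `CCOCC(C)Oc1cccc2ccc(N)nc12` gives 1070 nM, the highest number of the three. Its nearest neighbour on this read-out is compound 3, and the gap between the two lies beyond the usual scatter; compound 1 is furthest from it, and that gap is wider still. On the numbers shown, compound 2 is therefore the weakest inhibitor of the three.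

From compound 2 the account moves to compound 4 `Nc1ccc2cccc(OC3CCCC3)c2n1`, which has not yet been measured. The difference between the two structures is a group of 5 heavy atoms (5 carbon; one five-membered non-aromatic ring of carbon only) in place of a group of 6 heavy atoms (5 carbon, 1 oxygen; no ring), on an oxygen on an aromatic ring. Among the measured compounds shown here, no pair of measured compounds differing in a single place is available, so the size of this step cannot be read off directly. Compound 1 and compound 3, which both carry a ring-bearing group on the same oxygen, give markedly lower numbers than compound 2 in this assay, so a step downward that goes beyond the scatter is expected.

Compound 4 is expected to give about 80 nM in this assay, in a range from 25 nM to 250 nM. This estimate means a step of a 13-fold lower number from compound 2 to compound 4 (1.13 log units; beyond the scatter).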

Compound 4, half-maximal inhibitory concentration: > 2000 nM
Compound 4 gave a limit, no number (the forecaster's own chance of this, stated with the estimate: 3%); at least 25-fold (1.39 log units) between middle value and limit.
By their numbers in this assay, from the lowest: compound 1; then compound 3; then compound 2. At a limit, above all of these: compound 4.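

Compound 4 stands at a limit, not a number, in this assay: the limit of > 2000 nM in this assay, at which 1 of the 4 values shown sits.

Going by these compounds, on an oxygen on an aromatic ring, cyclopentyl in place of the open chain of compound 2 gives an at least 1.8-fold higher number from compound 2 to compound 4 (0.27 log units; that floor lies within the scatter), so this change brings no lowering of the number, and how far it raises the number stays unknown. The earlier compounds shown here alone left room to read a carbon ring on this oxygen as enough for a low number, since compound 1 gives 32 nM and compound 3 gives 137 nM, but compound 4 carries such a ring and goes against that reading, which shows that the kind of ring matters at this position and that a ring as such does not decide the result.

The compounds shown leave open what separates the groups of compound 1 and compound 3 from cyclopentyl, whether ring size, the extra carbon on the ring of compound 1 or the carbon link and bridged ring of compound 3. A plain cyclohexyl, a cyclopentylmethyl or a methylcyclopentyl on the same oxygen would bear on that question, and none of these stands among the compounds here.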